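This account rests on a few compounds, and the source may have more. Where it says the series, first, only, none or still open, it means among the compounds named here.

Measured compounds:
Compound 1, `CCOC(=O)[C@@H]1CCCN(S(=N)(=O)c2ccc(S(=O)(=O)N(CC)CC)cc2)C1`: in a functional assay on MIA PaCa-2 cells (Homo sapiens) for inhibition, read by MTT assay, with a stated time of 3 days (on this read-out higher numbers stand for weaker inhibition and lower numbers for stronger inhibition), compound 1 gives only a limit, > 10000 nM.
Compound 2, `CC(C)c1noc(N2CCN(C(=O)[C@@H]3CCCN(S(=O)(=O)c4ccc(S(=O)(=O)C5CCC5)cc4)C3)CC2)n1`: in this assay compound 2 gives only a limit, > 10000 nM.
Compound 3, `CCOC(=O)C1CN(S(=O)(=O)c2ccc(S(=O)(=O)N(CC)CC)cc2)C1`: in this assay compound 3 gives only a limit, > 10000 nM.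

Every value shown sits at the limit of > 10000 nM in this assay, at which 3 of the 3 values shown sit, so compound 2 is not set apart from compound 1 or compound 3 on the numbers: none of the three gives a number, each only a limit. Compound 4, `CC(C)NS(=O)(=O)c1ccc(S(=O)(=O)N2CCC[C@@H](C(=O)N3CCN(c4nc(C(C)C)no4)CC3)C2)cc1`, has not yet been measured. It differs from compound 2 in a single place: isopropylamino in place of cyclobutyl on a sulfonyl sulfur. Among the compounds with values here, no step between two measured compounds with numbers is available, so nothing shows how this change bears on the read-out of this assay. The expected step is therefore a step that the limit leaves unreadable from compound 2 to compound 4, taken as no movement beyond the scatter. For compound 4 the estimate in this assay is 15000 nM, with an expected range from 4000 nM to 60000 nM, and the more likely outcome is that compound 4 is again reported as a limit rather than a number.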

Compound 4, half-maximal inhibitory concentration: > 10000 nM
Compound 4 ended at the assay's limit; the forecaster's own chance of this, stated with the estimate: 80%; the middle value is on the limit's open side.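

In this assay compound 4 gives > 10000 nM, a limit and not a number. Compound 2 also gives only a limit, so no step can be read between compound 2 and compound 4: the limit of > 10000 nM in this assay, at which 4 of the 4 values shown sit. The compounds shown leave open how any structural change among them bears on the read-out.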